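Removing the Carboxyethyl Chain from a Core at the Limit

The source may hold more compounds than are shown below. What is called first, only, known or untested is meant among the compounds shown, and "the series" means these compounds.

Compound 1 `C[C@H]1N=C2C[C@H]3C[C@H](C3(C)C)[C@@]2(C)OC1=O`: > 1800000 nM
Compound 2 `CC1(C)[C@H]2CC3=N[C@H](CCC(=O)O)C(=O)O[C@]3(C)[C@@H]1C2`: > 1200000 nM

In an ADME assay on MCF-10A cells (Homo sapiens) for antiproliferative activity, read by sulforhodamine B assay, with a stated time of 48 h (on this read-out higher numbers stand for weaker inhibition and lower numbers for stronger inhibition), compound 1 gives only a limit, > 1800000 nM. In this assay compound 2 likewise gives only a limit, > 1200000 nM. Neither of these is a measured number, so compound 2 cannot be placed above or below compound 1; both simply sit at the limits (the limit of > 1200000 nM in this assay, at which 1 of the 2 values shown sits, and (the limit of > 1800000 nM in this assay, at which 1 of the 2 values shown sits)).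

Compound 3 `CC1(C)[C@H]2CC3=NCC(=O)O[C@]3(C)[C@@H]1C2` differs from compound 2 by hydrogen in place of 2-carboxyethyl on a saturated ring carbon. For the measured compounds named here, the one measured step, a step that the two limits leave unreadable from compound 1 to compound 2, is unreadable: both of its ends are limits. It therefore gives no size in either direction for taking the 2-carboxyethyl chain off again. With no readable step and both measured neighbours at limits, compound 3 is expected to sit at a limit as well, with no change beyond the scatter.

The estimate for compound 3 in this assay is 1500000 nM (500000 nM to 5000000 nM). That estimate corresponds to an expected step that the limit leaves unreadable from compound 2 to compound 3.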

Compound 3, half-maximal inhibitory concentration: > 2000000 nM
Compound 3 ended at the assay's limit (the forecaster's own chance of this, stated with the estimate: 85%); middle value at least 1.3-fold (0.12 log units) away from the limit.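

Compound 1, compound 2 and compound 3 each give only a limit in this assay, so no step among these three compounds can be read. The compounds shown leave open how strongly any of them inhibits cell growth, and whether the 2-carboxyethyl chain makes any difference to this read-out.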